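The compounds below may be only part of what the source reports. "The series", "measured", "known", "first", "only" and "open" are said of these compounds alone.

Of the compounds shown here, two have been measured in an assay on isolated protein with prostaglandin E2 receptor EP1 subtype (Homo sapiens) as the target, read by FLIPR, tested at 10 uM; on this read-out lower numbers stand for a weaker effect and higher numbers for a stronger effect at the one concentration tested. Compound 1, `Cc1cn(Cc2ccc(Cl)cc2Cl)c2c(-c3nnc(NS(=O)(=O)c4cc(F)c(F)cc4F)o3)cc(F)cc12`, gives 99%, and compound 2, `Cc1cn(Cc2ccc(Cl)cc2Cl)c2c(-c3nnc(NS(=O)(=O)c4ccc(Cl)c(Cl)c4)o3)cc(F)cc12`, gives 100%. Among the compounds with values here, the one measured step, a number 1 percentage points higher from compound 1 to compound 2 (within the scatter), means compound 2 stands at the head of the two numbers only nominally, since its difference from compound 1 is within the scatter and the two cannot be told apart.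

Compound 3 is `Cc1cn(Cc2ccc(Cl)cc2Cl)c2c(-c3nnc(NS(=O)(=O)c4ccc(F)c(F)c4)o3)cc(F)cc12`. Its difference from compound 2 is 3,4-difluorophenyl in place of 3,4-dichlorophenyl on a sulfonyl sulfur. Within the data shown here, the only step that bears on this change is the one from compound 1 to compound 2, where a different halogenated phenyl on the same sulfonyl sulfur was exchanged and the read-out did not move beyond the scatter. By that step, no change beyond the scatter is expected here either, giving a number 3 percentage points lower from compound 2 to compound 3 (within the scatter). Compound 3 is therefore estimated at 97%, in a range from 88% to 100%.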

Compound 3, a percentage reported as activity, at one concentration (the size of the read-out at that concentration, not a potency): 100%
Compound 3: the middle estimate sits 3 percentage points below what was measured; the measured number falls inside the stated range.
By their numbers in this assay, from the lowest: compounds 1, 2 and 3 (each within the scatter of the next).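

In this assay the exchange of 3,4-dichlorophenyl for 3,4-difluorophenyl on a sulfonyl sulfur gives no change at the digits printed from compound 2 to compound 3 (within the scatter) and so shows that this position tolerates a swap of both chlorines for fluorines with no detectable loss. Hydrogen in place of fluoro on an aromatic carbon gives a number 1 percentage points higher from compound 1 to compound 3 (within the scatter) and adds that the number of fluoro groups on this phenyl, here going from three to two, also leaves the read-out unmoved. No measurement is available to explain why these exchanges make no visible difference.

As far as these compounds go, whether the read-out would hold with a methoxy group, an amine or a carboxylic acid on this phenyl, or with a plain alkyl chain in place of the phenyl, remains open. A single concentration gives no potency, so any differences among these compounds at lower concentrations also remain unknown.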